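This account rests on a few compounds, and the source may have more. Where it says the series, first, only, none or still open, it means among the compounds named here.

Going by the values given here, compound 1 `O=C1/C(=C\c2ccc(O)cc2)c2ccccc2N1c1c(Cl)cccc1Cl` stands at the lowest number of the three compounds measured so far: in a functional assay on MIA PaCa-2 cells (Homo sapiens) for cytotoxicity, read by MTT assay, with a stated time of 72 h (a higher number here means that more compound is needed for the effect, a lower number that less compound is needed), compound 1 gives 2 ug/mL. Compound 2 `O=C1/C(=C\c2ccc(F)cc2)c2ccccc2N1c1c(Cl)cccc1Cl` gives 5 ug/mL in this assay, and compound 3 `O=C1/C(=C\c2cccc(Cl)c2)c2ccccc2N1c1c(Cl)cccc1Cl` gives 5 ug/mL in this assay. The two measured steps that start from compound 1 both run the same way: a 2.5-fold higher number from compound 1 to compound 2 (0.40 log units; beyond the scatter) and a 2.5-fold higher number from compound 1 to compound 3 (0.40 log units; beyond the scatter). Between the other two compounds nothing moves, since no change at the digits printed from compound 2 to compound 3 (within the scatter).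

Compound 4 `O=C1/C(=C\c2ccc(Cl)cc2)c2ccccc2N1c1c(Cl)cccc1Cl` differs from compound 1 in one place: chloro in place of hydroxy on an aromatic carbon. Among the compounds with values here, the closest precedent is the step from compound 1 to compound 2, where a halogen also took the place of the hydroxy group on that ring and the number went up by a modest amount in this assay. The step to compound 3, a different chlorophenyl group in place of the same 4-hydroxyphenyl, moved the number by the same amount in the same direction. On this basis compound 4 is expected to show a modest rise in this assay relative to compound 1, of the order of a 2.5-fold higher number from compound 1 to compound 4 (0.40 log units; beyond the scatter). The value estimated for compound 4 in this assay is therefore 5 ug/mL, with a range from 2 ug/mL to 12 ug/mL.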

Compound 4, concentration for half-maximal effect: 5 ug/mL
For compound 4 middle estimate and measured number coincide at the digits printed, within the range that was stated.
By their numbers in this assay, from the lowest: compound 1; then compounds 2, 3 and 4 (each within the scatter of the next).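

With chloro in place of hydroxy on this aromatic carbon, para to a large group, the result is a 2.5-fold higher number from compound 1 to compound 4 (0.40 log units; beyond the scatter) in this assay and matches the rise already seen with fluoro at the same place. Exchanging one halogen for the other shows no change at the digits printed from compound 2 to compound 4 (within the scatter) and exchanging 3-chlorophenyl for 4-chlorophenyl shows no change at the digits printed from compound 3 to compound 4 (within the scatter), so among these compounds neither the choice of halogen between fluoro and chloro nor the two chlorine placements separates the numbers, and only compound 1, with its hydroxy, stands apart from the other three. Nothing measured here accounts for the difference between the hydroxy compound and the halogen compounds.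

From the compounds shown here alone, it remains open whether the lower number of compound 1 belongs to hydroxy alone or would also appear with a methoxy group, an amine or a carboxylic acid on the same aromatic carbon. The compounds shown also leave open how far this pattern would hold with any change elsewhere on the shared core, since all four keep the rest of that core unchanged.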